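The source may report more compounds than this note shows. Statements on the series, on what has been measured and on what is new or still open speak of the compounds shown alone.

In a functional assay on PC-3 cells (Homo sapiens) for antiproliferative activity, read by MTT assay, with a stated time of 72 h (a higher number here means a weaker inhibitor, a lower number a stronger inhibitor), compound 1 `O=C(N/N=C/c1ccc(F)cc1)Nc1ccc(Oc2ccnc3[nH]ccc23)cc1` gives 7490 nM and compound 3 `CN(C)CCn1cccc1/C=N/NC(=O)Nc1ccc(Oc2ccnc3[nH]ccc23)cc1` gives 3930 nM, two values within the scatter of each other. Compound 2 `COc1ccc(/C=N/NC(=O)Nc2ccc(Oc3ccnc4[nH]ccc34)cc2)cc1` is recorded as "not active" (no number reported), with no number to compare. Compound 4 `CN(C)CCCn1cccc1/C=N/NC(=O)Nc1ccc(Oc2ccnc3[nH]ccc23)cc1` alters the side chain of compound 3: (dimethylamino)methyl in place of dimethylamino on a saturated chain carbon, two bonds along the chain from an aromatic nitrogen. This turns 2-(dimethylamino)ethyl into 3-(dimethylamino)propyl. Among the measured compounds shown here, the only measured step is a 1.9-fold lower number from compound 1 to compound 3 (0.28 log units; within the scatter). It lies within the scatter and changes a different part of the structure, so no measurement tests this chain change directly. With compound 3 as the closest reference, the expected outcome is a 1.0-fold higher number from compound 3 to compound 4 (0.01 log units; within the scatter), which means no shift beyond the scatter. For compound 4, the estimated value is 4000 nM, with an expected range of 1800 nM to 9000 nM.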

Compound 4, half-maximal inhibitory concentration: 5150 nM
Estimate against measurement, compound 4: 1.3-fold (0.11 log units) below, and the stated range covers the measured number.
By their numbers in this assay, from the lowest: compounds 3, 4 and 1 (each within the scatter of the next).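

Going from 2-(dimethylamino)ethyl to 3-(dimethylamino)propyl on the pyrrole nitrogen gives a 1.3-fold higher number from compound 3 to compound 4 (0.12 log units; within the scatter) in this assay and so directly tests chain length here: these two lengths are not separated. Placing the longer-chain group where compound 1 has 4-fluorophenyl gives a 1.5-fold lower number from compound 1 to compound 4 (0.16 log units; within the scatter) and again leaves no separation. No measurement here accounts for these results. Still open, going by these compounds, is whether a longer chain such as 4-(dimethylamino)butyl, or a morpholine at the chain end, would move the number beyond the scatter.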